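The compounds below may be only part of what the source reports. "The series", "measured", "known", "first", "only" and "open" are said of these compounds alone.

Working notes on the series

Of the compounds shown here, two have numbers so far, and they share one core. Going by the values given here, compound 1 `CCCCS(=O)(=O)Nc1cc(-c2ccc3ncnc(Nc4ccc(OCCO)nc4)c3c2)cnc1OC` is the first. In a functional assay on HCT-116 cells (Homo sapiens) for antiproliferative activity, read by sulforhodamine B assay, with a stated time of 72 h (on this read-out higher numbers stand for weaker inhibition and lower numbers for stronger inhibition), compound 1 gives only a limit, > 20000 nM, and nothing more can be read from it; the evidence here is the limit of > 20000 nM in this assay, at which 1 of the 2 values shown sits. Compound 2 `COc1ncc(-c2ccc3ncnc(Nc4ccc(OCCO)c(F)c4)c3c2)cc1NS(=O)(=O)c1ccc(F)cc1F` is the second. In this assay, among the compounds with values here, compound 2 gives 9160 nM, which is the only plain number in hand, so compound 2 stands as the sole fixed point and no ordering among the measured compounds can be stated.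

Compound 3 `COc1cc(Nc2ncnc3ccc(-c4cnc(OC)c(NS(=O)(=O)c5ccc(F)cc5F)c4)cc23)ccc1OCCO` is not yet measured. It differs from compound 2 in one place: methoxy in place of fluoro on an aromatic carbon, which in words is methoxy in place of fluoro on an aromatic carbon, ortho to a 2-hydroxyethoxy group and meta to a large group; cut one bond further out it reads 3-fluoro-4-(2-hydroxyethoxy)phenyl to 4-(2-hydroxyethoxy)-3-methoxyphenyl. Within the data shown here, no measured pair in the set shows a change of this kind, so the size of the step has no precedent here.

The step from compound 2 to compound 3 in this assay is expected to be a 1.1-fold lower number from compound 2 to compound 3 (0.06 log units; within the scatter), which would not go beyond the usual scatter. Compound 3 in this assay is therefore estimated at 8000 nM, with a range from 3000 nM to 20000 nM.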

Compound 3, half-maximal inhibitory concentration: 5720 nM
Compound 3: the middle estimate sits 1.4-fold (0.15 log units) above what was measured; the measured number falls inside the stated range.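

In this assay, going by these compounds alone, methoxy in place of fluoro on an aromatic carbon, ortho to a 2-hydroxyethoxy group and meta to a large group, gives a 1.6-fold lower number from compound 2 to compound 3 (0.20 log units; within the scatter), which is the first step that can be read at all. Methoxy, with its 2 heavy atoms and 1 hydrogen-bond acceptor as counted, stands where fluoro stood, yet on this read-out the 3-fluoro-4-(2-hydroxyethoxy)phenyl and 4-(2-hydroxyethoxy)-3-methoxyphenyl forms cannot be told apart. No measured property in hand bears on this step, so it carries no explanation.

From the compounds shown here alone, whether a different group at this position, such as an amine, a carboxylic acid or a longer alkoxy chain, would move the number beyond the scatter remains open. Also open, going by these compounds, is whether methoxy in place of fluoro would read the same way alongside the butyl sulfonyl group of compound 1, as this single step is all the evidence for the position.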